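The compounds below may be only part of what the source reports. "The series", "measured", "known", "first", "only" and "open" are said of these compounds alone.

Measured compounds:
compound 1, `CCC(c1ccccc1)c1nc(-c2ccc(Cl)cc2)c(CC(=O)O)s1` — 190 nM
compound 2, `O=C(O)Cc1sc(C(c2ccc(F)cc2)c2ccc(F)cc2)nc1-c1cn[nH]c1` — 16 nM

In an in vitro assay on HEK385-7 cells for displacement of a labelled ligand from prostaglandin D2 receptor 2 (Homo sapiens) (a higher number here means a weaker inhibitor, a lower number a stronger inhibitor), compound 1 gives 190 nM, the higher of the two numbers; compound 2 gives 16 nM, and the gap between them lies beyond the scatter. Compound 2 differs from compound 1 in more than one place, so no single change can be read from that pair.

Compound 3, `O=C(O)Cc1sc(C(c2ccccc2)c2ccc(F)cc2)nc1-c1ccc(Cl)cc1`, is not yet measured. It differs from compound 1 by 4-fluorophenyl in place of ethyl on a saturated chain carbon bound to two aromatic carbons. Going by the values given here, no step between measured compounds that differ in one place is known, so the size of this step is open. Given that compound 2, which gives 16 nM, carries two aromatic rings on the same saturated chain carbon, the account expects the step from compound 1 to compound 3 to go toward a lower number, with an expected size of a 3.8-fold lower number from compound 1 to compound 3 (0.58 log units; beyond the scatter), beyond the scatter but short of the whole gap to compound 2. For compound 3 the estimate in this assay is 50 nM, with a range from 15 nM to 160 nM.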

Compound 3, half-maximal inhibitory concentration: 17 nM
Beside the measured number, compound 3's estimate is 2.9-fold (0.47 log units) above it, and the stated range covers the measured number.
By their numbers in this assay, from the lowest: compounds 2 and 3 (each within the scatter of the next); then compound 1.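

In this assay, going by these compounds alone, the exchange of ethyl for 4-fluorophenyl on a saturated chain carbon bound to two aromatic carbons comes out as an 11-fold lower number from compound 1 to compound 3 (1.05 log units; beyond the scatter) and is the first single change that can be read in this set. It shows that this position is sensitive to what it carries: with the rest of compound 1 unchanged, this one exchange is large and lies well beyond the scatter. The pairing of compound 2 and compound 1 could not show this, since those two differ in more than one place, and compound 3 and compound 2 also differ in more than one place, so their closeness within the scatter assigns no effect to any single group.

The compounds shown give no measured basis for explaining why this step is so large. They also leave open whether the ring itself or its fluorine carries the change, and whether plain phenyl, cyclohexyl, a longer chain or an amine on the same carbon would give a step of similar size.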